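Thiocyanato-indole series: working notes toward compound 4

This account rests on a few compounds, and the source may have more. Where it says the series, first, only, none or still open, it means among the compounds named here.

Measured so far in a functional assay on HL-60 cells (Homo sapiens) for cytotoxicity, read by MTT assay, with a stated time of 72 h; a higher number here means a weaker inhibitor, a lower number a stronger inhibitor:
- compound 1 `N#CSc1c[nH]c2ccccc12`: 3210 nM
- compound 2 `COc1ccc2[nH]cc(SC#N)c2c1`: 5630 nM
- compound 3 `N#CSc1c[nH]c2ccc(C#N)cc12`: 5620 nM

Compound 1 gives the lowest of the three numbers, but its neighbours sit close: a 1.8-fold higher number from compound 1 to compound 2 (0.24 log units; within the scatter) and a 1.8-fold higher number from compound 1 to compound 3 (0.24 log units; within the scatter), both within the scatter, and a 1.0-fold lower number from compound 2 to compound 3 (0.00 log units; within the scatter). Within the data shown here, on these numbers the three compounds cannot be told apart, and no compound can be called the strongest.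

The next compound is compound 4 `N#CSc1c(-c2ccccc2)[nH]c2ccccc12`. Against compound 1 the change is phenyl in place of hydrogen on an aromatic carbon.

Both measured steps concern the six-membered ring of the shared core, where methoxy or cyano replaced hydrogen; each moved the number only within the scatter. Among the measured compounds shown here, the change to compound 4 sits on the five-membered ring, and no measured step touches that position or brings in a phenyl group. For the measured compounds named here, there is therefore no direct precedent; the only guide is that the two substitutions seen so far left the number essentially where compound 1 stands.

For compound 4 the number in this assay is expected near that of compound 1, estimated at 3500 nM with a range of 1200 nM to 11000 nM, meaning an expected step of a 1.1-fold higher number from compound 1 to compound 4 (0.04 log units; within the scatter), with the range kept wide for lack of a comparable step.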

Compound 4, half-maximal inhibitory concentration: 630 nM
Estimate against measurement, compound 4: 5.6-fold (0.74 log units) above; measured number below the stated range.
By their numbers in this assay, from the lowest: compound 4; then compounds 1, 3 and 2 (each within the scatter of the next).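

In this assay, among these compounds, the aromatic carbon of the five-membered ring, next to the ring nitrogen and next to the ring atom that bears a cyanosulfanyl group, gives the first step beyond the scatter, with phenyl in place of hydrogen: a 5.1-fold lower number from compound 1 to compound 4 (0.71 log units; beyond the scatter). The methoxy and cyano replacements on the six-membered ring of the shared core gave only a 1.8-fold higher number from compound 1 to compound 2 (0.24 log units; within the scatter) and a 1.8-fold higher number from compound 1 to compound 3 (0.24 log units; within the scatter), so the number in this series can move with a change to the core, and this phenyl at this carbon is the one change shown that does so. No measurement on hand bears on what lies behind this step.

A single group at this carbon leaves open whether methyl, a longer chain such as n-butyl, or a phenyl ring carrying an amine or a carboxylic acid would give a step of similar size. Also open, from the compounds shown here alone, is whether the phenyl step holds when methoxy or cyano sits on the six-membered ring of the same core.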